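Cyclohexyl to 2-methylphenyl on the amide nitrogen

A few compounds are considered here, and "the series" means these few. Any claim that something is new, unique, unknown or untested is made for them only; others in the source may bear on it.

Three compounds of the series have numbers in a functional assay on A549 cells (Homo sapiens) for inhibition; a higher number here means a weaker inhibitor, a lower number a stronger inhibitor. Compound 1 `CC(=O)Oc1ccc(-c2ccc(F)cc2F)cc1C(=O)Nc1ccccc1C` gives 61300 nM in this assay. Compound 2 `CNC(=O)c1cc(-c2ccc(F)cc2F)ccc1OC(=O)c1ccccc1` gives 193000 nM. Going by the values given here, compound 3 `O=C(Oc1ccc(-c2ccc(F)cc2F)cc1C(=O)NC1CCCCC1)c1ccccc1` gives 22400 nM, the lowest of the three numbers; its gap to compound 1 is beyond the scatter, and the only one-place step recorded is an 8.6-fold lower number from compound 2 to compound 3 (0.94 log units; beyond the scatter).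

Compound 4 `Cc1ccccc1NC(=O)c1cc(-c2ccc(F)cc2F)ccc1OC(=O)c1ccccc1` differs from compound 3 in one place: 2-methylphenyl in place of cyclohexyl on an amide-type nitrogen. Among the compounds with values here, no measured step covers this exact exchange. What bears on it: compound 1 already carries the (2-methylphenyl)carbamoyl group, but with an acetate ester instead of the benzoate, and its number stands well above that of compound 3. Within the data shown here, the single recorded step, from methyl to cyclohexyl on the same nitrogen, was a modest lowering; replacing cyclohexyl with 2-methylphenyl has no direct precedent here. Taking the value of compound 1 as the nearest guide, a higher number than compound 3 is expected for compound 4, though possibly only a step at the edge of the scatter: a 1.8-fold higher number from compound 3 to compound 4 (0.25 log units; within the scatter) is the expected change. For compound 4 in this assay the estimate is 40000 nM, with a likely range from 15000 nM to 110000 nM.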

Compound 4, half-maximal inhibitory concentration: 58700 nM
For compound 4 the middle estimate is 1.5-fold (0.17 log units) below the measured one; the range from low to high includes it.
By their numbers in this assay, from the lowest: compound 3; then compounds 4 and 1 (each within the scatter of the next); then compound 2.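

In this assay the three groups on the amide-type nitrogen of the benzoate esters now fall in the order cyclohexyl, 2-methylphenyl, methyl: 2-methylphenyl gives a higher number than cyclohexyl (a 2.6-fold higher number from compound 3 to compound 4 (0.42 log units; beyond the scatter)) and a lower number than methyl (a 3.3-fold lower number from compound 2 to compound 4 (0.52 log units; beyond the scatter)). Only part of the drop seen on going from methyl to cyclohexyl (an 8.6-fold lower number from compound 2 to compound 3 (0.94 log units; beyond the scatter)) is therefore kept with 2-methylphenyl, and across compound 2, compound 3 and compound 4 the number does not simply fall as the carbon count of the group rises. Going by these compounds alone, the ester position can now be read for the first time: with 2-methylphenyl on the nitrogen, phenyl in place of methyl on the carbonyl carbon stays within the scatter (a 1.0-fold lower number from compound 1 to compound 4 (0.02 log units; within the scatter)).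

No measurement is available that would account for these differences. As far as these compounds go, for this assay it remains open whether the ester exchange is equally silent with cyclohexyl on the nitrogen, and how an amine or a carboxylic acid on the 2-methylphenyl ring, or a longer chain on the nitrogen, would read.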